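Two compounds at the assay ceiling, a third awaited

The source may hold more compounds than are shown below. What is called first, only, known or untested is meant among the compounds shown, and "the series" means these compounds.

Compound 1 `Fc1cccc(Nc2nc(-c3cccc(F)c3)nc3ccc(F)cc23)c1` and compound 2 `Fc1cccc(-c2nc(Nc3ccccc3Br)c3cc(F)ccc3n2)c1` share one core and differ only in the group attached to a nitrogen on an aromatic ring. Both were tested in a functional assay on COLO 205 cells (Homo sapiens) for cytotoxicity, read by MTT assay, with a stated time of 48 h; on this read-out lower numbers stand for stronger inhibition and higher numbers for weaker inhibition. In this assay compound 1 gives > 50000 nM, which is a limit of the assay rather than a number. Compound 2 likewise gives > 50000 nM, again a limit. The step that the two limits leave unreadable from compound 1 to compound 2 therefore cannot be sized, and the position of compound 2 is known only as a ceiling; the limit of > 50000 nM in this assay, at which 2 of the 2 values shown sit, describes where both values sit.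

Compound 3 `Oc1cccc(Nc2nc(-c3cccc(F)c3)nc3ccc(F)cc23)c1` is the next member, differing from compound 2 by 3-hydroxyphenyl in place of 2-bromophenyl on a nitrogen on an aromatic ring. No measured step can be read for size, so nothing indicates whether this change should move the read-out or by how much. Given that compound 2 sits at the limit, the expectation for compound 3 is that it too is likely to sit near or beyond that limit, estimated at 60000 nM, within a range from 10000 nM to 300000 nM. This corresponds to an expected step that the limit leaves unreadable from compound 2 to compound 3.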

Compound 3, half-maximal inhibitory concentration: > 50000 nM
Compound 3: only a limit was reported (the forecaster's own chance of this, stated with the estimate: 70%); the middle value lies beyond the limit too.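

No step among compound 1, compound 2 and compound 3 can be read, since all three sit at the same limit rather than at a number: the limit of > 50000 nM in this assay, at which 3 of the 3 values shown sit.

From the compounds shown here alone, what stays open is how far each of the three compounds lies beyond that limit, and so whether their differing groups change the read-out at all.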